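The source may hold more compounds than are shown below. What is called first, only, known or untested is meant among the compounds shown, and "the series" means these compounds.

Measured in an ADME assay on the whole organism (strain CD1) for pharmacokinetics, with Mus musculus as the target, read by LC-MS, at a dose of 5 mg/kg by the oral route; on this read-out lower numbers stand for lower exposure and higher numbers for higher exposure at the dose given:
compound 1 `CCC[C@H](CO)NC(=O)c1cnc(Oc2ccc3c(c2C)B(O)OC3)cn1`: 21600 ng.h/mL
compound 2 `Cc1c(Oc2cnc(C(=O)N[C@@H](CO)CC(F)(F)F)cn2)ccc2c1B(O)OC2`: 13400 ng.h/mL

Only these two numbers exist so far, and compound 2 cannot be told apart from compound 1 on them. Compound 3 `Cc1c(Oc2cnc(C(=O)N3CC(C)(O)C3)cn2)ccc2c1B(O)OC2` keeps the shared core but changes what sits on the carbonyl carbon: 3-hydroxy-3-methylazetidin-1-yl in place of (3,3,3-trifluoro-1-(hydroxymethyl)propyl)amino (3-hydroxy-3-methylazetidin-1-yl in place of (3,3,3-trifluoro-1-(hydroxymethyl)propyl)amino on a carbonyl carbon). Among the measured compounds shown here, one measured step bears on this, and only loosely: a 1.6-fold lower number from compound 1 to compound 2 (0.21 log units; within the scatter). For the measured compounds named here, that step swapped a single group on the chain, whereas the new change replaces the whole chain, and no measured compound carries a ring in this place. The step therefore offers no direction of its own, so no change beyond the scatter is expected, though with a wide margin on both sides. The expected step is a 1.3-fold lower number from compound 2 to compound 3 (0.13 log units; within the scatter). The value expected for compound 3 is 10000 ng.h/mL, within an estimated range of 3500 ng.h/mL to 28000 ng.h/mL.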

Compound 3, area under the concentration-time curve: 20700 ng.h/mL
For compound 3 the middle estimate is 2.1-fold (0.32 log units) below the measured one; the measured number falls inside the stated range.
By their numbers in this assay, from the lowest: compounds 2, 3 and 1 (each within the scatter of the next).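

In this assay, among the compounds shown here, putting a ring at this place for the first time gives a 1.5-fold higher number from compound 2 to compound 3 (0.19 log units; within the scatter), so the open chain of compound 2 can give way to the smaller 3-hydroxy-3-methylazetidin-1-yl without a change that can be told from the scatter. Set against the (1-(hydroxymethyl)butyl)amino chain of compound 1, the same ring gives a 1.0-fold lower number from compound 1 to compound 3 (0.02 log units; within the scatter), which shows that, among these three compounds, neither the open chain, the fluorine atoms of compound 2 nor the defined stereocentre is needed for exposure in this range. Nothing available here accounts for these values.

Still open, from the compounds shown here alone, is whether the exposure would hold with a plain azetidine ring lacking the hydroxyl and methyl groups, with a larger piperidine ring, or with a carboxylic acid in place of the hydroxyl. A single oral exposure number also cannot separate how much of a dose is absorbed from how quickly it is cleared, so either could differ among these compounds.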